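This account rests on a few compounds, and the source may have more. Where it says the series, first, only, none or still open, it means among the compounds named here.

Compound 1 `c1ccc2c(c1)CN[C@@H](CN(CCCCNCc1ccncc1)[C@H]1CCCc3cccnc31)C2` gives 22.7 nM in a functional assay on cells for antagonist activity at C-X-C chemokine receptor type 4 (Homo sapiens), read by fluorescence and calcium flux, with stated times of 25 min and 90 s; a lower number here means a stronger inhibitor, a higher number a weaker inhibitor.
Compound 2 `c1ccc(CNCc2ccc(CN(C[C@H]3Cc4ccccc4CN3)[C@H]3CCCc4cccnc43)cc2)nc1` gives 286 nM in this assay.

Of the two measured compounds, compound 1 has the lower number in this assay, and its gap to compound 2 lies beyond the usual scatter of the measurement. Compound 3 `C(=C/CN(C[C@H]1Cc2ccccc2CN1)[C@H]1CCCc2cccnc21)\CNCc1cccnc1` has not yet been measured. It differs from compound 1 in one place: a group of 11 heavy atoms (9 carbon, 2 nitrogen; one six-membered aromatic ring with 1 hetero atom) in place of a group of 11 heavy atoms (9 carbon, 2 nitrogen; one six-membered aromatic ring with 1 hetero atom), on a saturated chain carbon bound to an amine nitrogen. Within the data shown here, no pair of measured compounds differs in only one place, so there is no measured step of this kind to lean on. Among the measured compounds shown here, compound 2 shows that another group on the same amine nitrogen goes with a higher number, but that change is broader than the one leading to compound 3. A modest rise in the number, close to the edge of the scatter, is expected for the step of a 2.2-fold higher number from compound 1 to compound 3 (0.34 log units; beyond the scatter). Compound 3 is therefore estimated at 50 nM, with a range from 15 nM to 200 nM.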

Compound 3, half-maximal inhibitory concentration: 92.8 nM
Compound 3: the middle estimate sits 1.9-fold (0.27 log units) below what was measured, and the stated range covers the measured number.
By their numbers in this assay, from the lowest: compound 1; then compound 3; then compound 2.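

The position on the saturated chain carbon bound to an amine nitrogen proves sensitive even when the size of the group stays the same. In this assay, replacing the 3-(((pyridin-4-yl)methyl)amino)propyl group with one of equal heavy-atom count, the same ring type and the same donor and acceptor counts, but with a double bond outside aromatic rings, gives a 4.1-fold higher number from compound 1 to compound 3 (0.61 log units; beyond the scatter). Nothing available explains this loss.

The compounds shown do not separate the double bond from any other difference within the entering group, so its share of the step remains unknown. They also leave open how this position would respond to a longer chain, or to a simple primary amine in place of the pyridine-bearing end of the group.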